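Reversed enone and methoxyphenyl on a fused pyrazolo core

The compounds below may be only part of what the source reports. "The series", "measured", "known", "first", "only" and "open" are said of these compounds alone.

Measured compounds in a functional assay on MDA-MB-231 cells (Homo sapiens) for antiproliferative activity, read by MTT assay, with a stated time of 24 h; a higher number here means a weaker inhibitor, a lower number a stronger inhibitor:
- compound 1, `COc1ccc(-c2cc(C(=O)/C=C/c3cc(OC)c(OC)c(OC)c3)nc3cc(-c4ccccc4)nn23)cc1OC`, 16700 nM
- compound 2, `COc1cc(-c2cc(/C=C/C(=O)c3ccc(C)c(C)c3)nc3cc(-c4ccccc4)nn23)cc(OC)c1OC`, 13500 nM
- compound 3, `COc1cc(C(=O)/C=C/c2cc(-c3cc(OC)c(OC)c(OC)c3)n3nc(-c4ccccc4)cc3n2)cc(OC)c1OC`, 24300 nM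

Going by the values given here, compound 2 gives the lowest of the three numbers in this assay, but its two neighbours stand within the scatter of it: compound 1 differs from it by an amount too small to rank, and the single one-place step recorded, a 1.8-fold higher number from compound 2 to compound 3 (0.26 log units; within the scatter), also stays within the scatter. Compound 4, `COc1ccc(/C=C/C(=O)c2cc(-c3cc(OC)c(OC)c(OC)c3)n3nc(-c4ccccc4)cc3n2)cc1`, is not yet measured. It differs from compound 2 in one place, on an aromatic carbon of a six-membered aromatic ring with 2 nitrogen, part of a fused or bridged system of two rings: (2-(4-methoxyphenyl)ethenyl)carbonyl in place of 2-((3,4-dimethylphenyl)carbonyl)ethenyl on an aromatic carbon. Among the compounds with values here, the only step that bears on this change is the one from compound 2 to compound 3, which swapped the aryl group on the same chain without moving beyond the scatter. Within the data shown here, the reversal of the chain's carbonyl and ethenyl order has no measured counterpart here. Compound 4 is therefore expected to lie close to compound 2, with a step of a 1.3-fold higher number from compound 2 to compound 4 (0.12 log units; within the scatter) that is not expected to exceed the scatter, giving an estimate of 18000 nM with a range from 8000 nM to 40000 nM.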

Compound 4, half-maximal inhibitory concentration: 16500 nM
Estimate against measurement, compound 4: 1.1-fold (0.04 log units) above; the range from low to high includes it.
By their numbers in this assay, from the lowest: compounds 2, 4, 1 and 3 (each within the scatter of the next).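

In this assay, the exchange at this aromatic carbon puts (2-(4-methoxyphenyl)ethenyl)carbonyl in place of 2-((3,4-dimethylphenyl)carbonyl)ethenyl and gives a 1.2-fold higher number from compound 2 to compound 4 (0.09 log units; within the scatter). Going by these compounds alone, this is the first step here in which the order of carbonyl and ethenyl in the chain is turned around, and with the aryl group exchanged in the same step, the number stays within the scatter. Nothing measured here offers an explanation for this result.

The compounds shown do not separate the reversal of the chain from the exchange of its aryl group, since the two occur together in this step. They also leave open what an amine, a carboxylic acid or a longer chain at this aromatic carbon would give in this assay.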